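Clearance notes on the cyclopentyl-to-cyclopentylamino switch

The compounds below may be only part of what the source reports. "The series", "measured", "known", "first", "only" and "open" are said of these compounds alone.

Measured so far in an in vitro ADME assay on microsomes from liver (Rattus norvegicus) for metabolic stability, read by LC-MS, tested at 0.05 uM; a lower number here means slower removal, a higher number faster removal of the compound:
compound 1, `COc1cnc(-c2ccccn2)nc1N1CCCC1`, 987 mL/min/kg
compound 2, `COc1cnc(-c2ccccn2)nc1C1CCCC1`, reported only as a limit of the assay
compound 3, `COc1cnc(-c2ccccn2)nc1NCc1ccccc1Cl`, 827 mL/min/kg

In this assay compound 2 gives > 1000 mL/min/kg, which is a limit of the assay and not a number. Compound 2 therefore stands at the ceiling of the series, (the limit of > 1000 mL/min/kg in this assay, at which 1 of the 3 values shown sits). Among the measured compounds shown here, the one step that touches the same carbon is an at least 1.0-fold higher number from compound 1 to compound 2 (0.00 log units; that floor lies within the scatter), a change within the scatter. For the measured compounds named here, compound 1 and compound 3 sit within the scatter of each other, so all three measured compounds are cleared quickly and no measured step here moves the number beyond the scatter.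

Compound 4, `COc1cnc(-c2ccccn2)nc1NC1CCCC1`, differs from compound 2 by cyclopentylamino in place of cyclopentyl on an aromatic carbon. The measured step that bears on this is an at least 1.0-fold higher number from compound 1 to compound 2 (0.00 log units; that floor lies within the scatter), read in reverse, since it also exchanges a nitrogen-linked ring for a carbon-linked one at this carbon; it was within the scatter. Compound 3, which also carries an amino-linked group at this carbon, gives 827 mL/min/kg. No step beyond the scatter is therefore expected in this assay for compound 4, in either direction. Compound 4 is expected to give 900 mL/min/kg, with a range from 450 mL/min/kg to 1000 mL/min/kg. That estimate means an at least 1.1-fold lower number from compound 2 to compound 4 (0.04 log units; that floor lies within the scatter), and a further reading at the limit is considered likely.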

Compound 4, clearance: 202 mL/min/kg
Beside the measured number, compound 4's estimate is 4.5-fold (0.65 log units) above it; the whole stated range lies above it.
By their numbers in this assay, from the lowest: compound 4; then compounds 3 and 1 (each within the scatter of the next). At a limit, above all of these: compound 2.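

Among the compounds shown here, the change at this aromatic carbon is the first to move the number in this assay beyond the scatter, with an at least 4.9-fold lower number from compound 2 to compound 4 (0.69 log units; beyond the scatter), and the direction is downward, towards slower removal. Compound 2 remains a limit of the assay and not a number, so that step gives only a floor: the limit of > 1000 mL/min/kg in this assay, at which 1 of the 4 values shown sits. A nitrogen at this carbon is not enough by itself: a 4.9-fold lower number from compound 1 to compound 4 (0.69 log units; beyond the scatter), although the pyrrolidin-1-yl group of compound 1 is also joined through nitrogen, and compound 3, which also carries an amino-linked group here, gives 827 mL/min/kg, so within these compounds the low number belongs to cyclopentylamino alone and not to amino-linked groups in general.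

On these data alone, it remains open whether the lower number holds when the ring on the amino link changes size, as in cyclobutylamino or cyclohexylamino, or gives way to an open chain such as isopropylamino. A methyl group on the linking nitrogen of cyclopentylamino would test whether that nitrogen's hydrogen matters, and the compounds shown do not tell which part of compound 4 is removed.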